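The source may report more compounds than this note shows. Statements on the series, on what has been measured and on what is new or still open speak of the compounds shown alone.

Measured so far in a functional assay on M14 cells (Homo sapiens) for cytotoxicity, read by sulforhodamine B assay, with a stated time of 48 h; on this read-out higher numbers stand for lower toxicity in this test and lower numbers for higher toxicity in this test:

Compound 1 `ClCc1cccc(Cn2cnc3c(Cl)nc(Cl)nc32)c1` gives 6450 nM.
Compound 2 `Nc1nc(Cl)c2ncn(Cc3ccc(CCl)cc3)c2n1` gives only a limit of the assay, > 100000 nM.

For the measured compounds named here, compound 1 is thus the one compound of the pair with a real number on this read-out; the other entry is the limit of > 100000 nM in this assay, at which 1 of the 2 values shown sits, which tells only that compound 2 is less toxic than the assay can resolve, not by how much. Going by the values given here, no pair of measured compounds differs in a single place, so no measured step can be read from these two alone.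

Compound 3 `ClCc1cccc(Cn2cnc3c(Cl)ncnc32)c1` differs from compound 1 by hydrogen in place of chloro on an aromatic carbon. The carbon that carries the change sits between two ring nitrogen atoms of the shared core, and the remaining chloro group on the core is kept.

Among the compounds with values here, with no measured step to lean on, the expected step of a 2.3-fold higher number from compound 1 to compound 3 (0.37 log units; beyond the scatter) is a modest loss of toxicity, going beyond the usual scatter but not by much. Compound 3 is therefore estimated at 15000 nM, with a range from 4000 nM to 60000 nM in this assay.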

Compound 3, concentration lethal to 50% of the cells: 6600 nM
For compound 3 the middle estimate is 2.3-fold (0.36 log units) above the measured one; the measured number falls inside the stated range.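

In this assay, putting hydrogen in place of chloro on the aromatic carbon between two ring nitrogen atoms gives a 1.0-fold higher number from compound 1 to compound 3 (0.01 log units; within the scatter) for this single change. For the compounds shown here, this is the first step in the set that can be read from two measured compounds, and it shows that, for this pair in this test, the chloro group at this place can be replaced by hydrogen without moving the read-out beyond the usual scatter of repeated measurements. The one limit value shown belongs to a compound that differs from this pair in more than one place, so nothing shown offers a reason for this result.

As far as these compounds go, the other chloro group on the core is present in both compound 1 and compound 3, so what happens when that group is replaced remains open. From the compounds shown here alone, it is also open whether a larger group at the carbon that carries the change, such as a methoxy group or a carboxylic acid, would leave the read-out just as unmoved as hydrogen does.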